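The source may report more compounds than this note shows. Statements on the series, on what has been measured and on what is new or still open speak of the compounds shown alone.

Compound 2 `ClC1=C(Cn2cc(-c3ccc(Cl)c(Cl)c3)nn2)CCc2nc(-c3cccs3)ccc21` gives > 300 ug/mL in an ADME assay on MDCK cells (Canis lupus familiaris) for cytotoxicity, read by MTT assay, with a stated time of 48 h (on this read-out lower numbers stand for higher toxicity in this test and higher numbers for lower toxicity in this test), a limit of the assay and not a number. That places compound 2 at the limit of > 300 ug/mL in this assay, at which 1 of the 2 values shown sits.

The next change leads to compound 3 `FC(F)(F)c1ccccc1-c1cn(CC2=C(Cl)c3ccc(-c4cccs4)nc3CC2)nn1`: 2-(trifluoromethyl)phenyl in place of 3,4-dichlorophenyl on an aromatic carbon.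

For the measured compounds named here, only one measured step bears on this place. Compound 1 `Fc1ccc(-c2cn(CC3=C(Cl)c4ccc(-c5cccs5)nc4CC3)nn2)c(F)c1` gives 188 ug/mL in this assay, and 3,4-dichlorophenyl in place of 2,4-difluorophenyl gives an at least 1.5-fold higher number from compound 1 to compound 2 (0.20 log units; that floor lies within the scatter). That single step has no upper bound and does not show how far a change of aryl group moves the read-out, so no step beyond the scatter is expected in this assay.

The estimated change is an at least 1.2-fold lower number from compound 2 to compound 3 (0.09 log units; that floor lies within the scatter).

Compound 3 is expected at 240 ug/mL, with an estimated range of 120 ug/mL to 450 ug/mL.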

Compound 3, half-maximal cytotoxic concentration: > 300 ug/mL
Compound 3: a limit, no number; the forecaster's own chance of this, stated with the estimate: 35%; middle value at least 1.2-fold (0.09 log units) away from the limit.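

In this assay compound 3 gives > 300 ug/mL, a limit of the assay and not a number. With 2-(trifluoromethyl)phenyl in place of 2,4-difluorophenyl on this aromatic carbon, the read-out shows an at least 1.5-fold higher number from compound 1 to compound 3 (0.20 log units; that floor lies within the scatter). The step between compound 2 and compound 3 cannot be read, and two different substituted phenyl groups at this place now end at the same limit: the limit of > 300 ug/mL in this assay, at which 2 of the 3 values shown sit.

Where the true values of compound 2 and compound 3 lie, and whether either differs from compound 1 by more than the scatter, stays open. Also open, from the compounds shown here alone, is what a group other than a substituted phenyl on this aromatic carbon, such as an amine, a carboxylic acid or a longer alkyl chain, would give in this assay.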